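The compounds below may be only part of what the source reports. "The series", "measured", "known", "first", "only" and "open" are said of these compounds alone.

Compound 1 `CCCCCNc1oc2c(C)ncc(CO)c2c1Nc1ccccn1` gives 5810 nM in a functional assay on HEK293 cells for agonist activity at Toll-like receptor 8 (Homo sapiens), read by reporter gene assay; a higher number here means that more compound is needed for the effect, a lower number that less compound is needed. Compound 2 `Cc1ncc(CO)c2c(Nc3ccccn3)c(NC(C)(C)CC(C)(C)C)oc12`, which carries a (1,1,3,3-tetramethylbutyl)amino group on the shared core, was reported as "not active" (no number reported) in this assay with no number, so it cannot be placed on the scale. Compound 3 `Cc1ncc(CO)c2c(Nc3ccccn3)c(NC(C)(C)C)oc12` differs from compound 2 by hydrogen in place of tert-butyl on a saturated chain carbon, two bonds along the chain from a nitrogen on an aromatic ring. Among the measured compounds shown here, no measured step covers this change; activity is expected to return toward the range of compound 1 at 5810 nM, while an outcome without a usable number, as for compound 2, remains a real possibility. Compound 3 is expected to give 6000 nM in this assay, within 1500 nM to 25000 nM.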

Compound 3, half-maximal effective concentration: "not active" (no number reported)
For compound 3 the study gives words and no number; no gap can be computed for the estimate.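

No new step can be read: compound 2 and compound 3 are both reported as "not active" in this assay, without a number. No available evidence bears on this result. The compounds shown leave open whether any branched amino chain on the shared core gives a measurable value.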